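Phenyl for thiophen-2-yl on the nucleoside core

The compounds below may be only part of what the source reports. "The series", "measured", "known", "first", "only" and "open" are said of these compounds alone.

This account follows compound 2 to compound 4 in a functional assay on HL-60 cells (Homo sapiens) for antiproliferative activity, read by XTT assay, with a stated time of 72 h; on this read-out lower numbers stand for stronger inhibition and higher numbers for weaker inhibition. The shared core is carried by compound 1 `O=c1[nH]cnc2c1c(-c1ccsc1)cn2[C@@H]1O[C@H](CO)[C@@H](O)[C@H]1O`, compound 2 `O=c1[nH]cnc2c1c(-c1cccs1)cn2[C@@H]1O[C@H](CO)[C@@H](O)[C@H]1O` and compound 3 `CN(C)c1ncnc2c1c(-c1cccs1)cn2[C@@H]1O[C@H](CO)[C@@H](O)[C@H]1O`. In this assay compound 1 gives 12000 nM. Compound 3 bears a dimethylamino group where compound 1 carries the lactam. In this assay compound 3 gives 11800 nM. Compound 2 reaches only the limit of the measurement, > 20000 nM, and so stands at the weak end of the numbers shown; one of the three values sits at the limit of > 20000 nM in this assay, at which 1 of the 3 values shown sits. Among the compounds with values here, the single measured step with one change, an at least 1.6-fold higher number from compound 1 to compound 2 (0.22 log units; that floor lies within the scatter), is small and rests on a limit. Compound 4 `O=c1[nH]cnc2c1c(-c1ccccc1)cn2[C@@H]1O[C@H](CO)[C@@H](O)[C@H]1O` differs from compound 2 as follows: phenyl in place of thiophen-2-yl on an aromatic carbon. Within the data shown here, no measured step exchanges a five-membered heteroaryl for phenyl at this position, so the expectation rests on the small effect of swapping one thiophene isomer for another and on the weak standing of compound 2. The author therefore expects no step beyond the scatter, with compound 4 estimated at 20000 nM, a range of 8000 nM to 50000 nM, which means a step of a number no higher from compound 2 to compound 4 (the limit leaves the size open) as the expected outcome.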

Compound 4, half-maximal inhibitory concentration: > 20000 nM
Compound 4: no number, only a limit (the forecaster's own chance of this, stated with the estimate: 55%); the middle value sits exactly at the limit.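

In this assay compound 4 gives > 20000 nM, which is a limit and not a number. Within the data shown here, the step between compound 2 and compound 4 cannot be read, with a limit on both sides, and the one new step that can be read is an at least 1.6-fold higher number from compound 1 to compound 4 (0.22 log units; that floor lies within the scatter). What the result adds is that phenyl, a six-membered aromatic ring of carbon only, behaves like thiophen-2-yl at this place on the lactam core in giving no readable number, and the weak end of the read-out now holds two different rings: the limit of > 20000 nM in this assay, at which 2 of the 4 values shown sit.

Going by these compounds, whether compound 2 and compound 4 differ at all, and how far past the limit either of them lies, stays open, as does whether any ring at this place can move the number beyond the scatter from the value of compound 1. On these data alone, what an amine or a carboxylic acid carried on the phenyl ring would do here, or a longer chain in place of the ring, also stays open.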